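The source may hold more compounds than are shown below. What is called first, only, known or untested is meant among the compounds shown, and "the series" means these compounds.

Series notes. Among the measured compounds shown here, compound 2 `COc1cc(OC)c(/C=C/S(=O)(=O)Nc2ccc(OC)c(F)c2)c(OC)c1` carries the lowest number so far: in a functional assay on DU-145 cells (Homo sapiens) for cytotoxicity, read by trypan blue exclusion, with a stated time of 96 h (a higher number here means a weaker inhibitor, a lower number a stronger inhibitor), compound 2 gives 200 nM. For the measured compounds named here, compound 1 `COc1ccc(/C=C/S(=O)(=O)Nc2c(OC)cc(OC)cc2OC)cc1` sits well apart from it; in this assay compound 1 gives 7500 nM, a gap clearly beyond the scatter, although no single step connects the two compounds and only the two values themselves can be compared. Compound 3 `COc1cc(OC)c(/C=C/S(=O)(=O)Nc2ccc(OC)c(NC(C(=O)O)c3ccc(Br)cc3)c2)c(OC)c1` follows from compound 2 by one change, (((4-bromophenyl)(carboxy)methyl)amino in place of fluoro on an aromatic carbon). Going by the values given here, no measured step of this kind exists, so the expectation rests on the amount of material entering in place of one heavy atom. The step of a 10-fold higher number from compound 2 to compound 3 (1.00 log units; beyond the scatter) in this assay is expected to be a sizeable one, pointing toward a weaker inhibitor. Compound 3 is accordingly estimated at 2000 nM in this assay, with a range of 300 nM to 15000 nM.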

Compound 3, half-maximal inhibitory concentration: 250 nM
Compound 3: middle estimate off by 8.0-fold (0.90 log units), on the high side; the measured number lies below the stated range.
By their numbers in this assay, from the lowest: compounds 2 and 3 (each within the scatter of the next); then compound 1.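

In this assay, putting ((4-bromophenyl)(carboxy)methyl)amino in place of fluoro gives a 1.3-fold higher number from compound 2 to compound 3 (0.10 log units; within the scatter), so no difference between the two compounds can be read. This aromatic carbon, ortho to a methoxy group, can therefore carry a group of 12 heavy atoms with a six-membered aromatic ring as well as a single fluorine, with the value staying within the scatter. Nothing available bears on the reason for this result.

The compounds shown leave open which part of the entering group matters, as the amino link, the carboxylic acid and the 4-bromophenyl ring all enter together. A plain amine at this carbon, or the same group with a methyl ester in place of the carboxylic acid or with an unsubstituted phenyl ring, would separate these parts.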